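A few compounds are considered here, and "the series" means these few. Any claim that something is new, unique, unknown or untested is made for them only; others in the source may bear on it.

Working notes on the series. Of the compounds shown here, two have numbers so far in an assay for inhibition of Indoleamine 2,3-dioxygenase 1 (Homo sapiens), with stated times of 10 min and 60 min, tested at 10 uM; a lower number here means a weaker effect, a higher number a stronger effect of the compound at the concentration tested. Compound 1 `NCCn1ncc2c(NCc3ccccc3[N+](=O)[O-])cc(C(F)(F)F)cc21` gives 9% in this assay, and compound 2 `CNC(=O)c1cccc(CNc2cc(C(F)(F)F)cc3[nH]ncc23)c1` gives 33%. Among the compounds with values here, compound 1 thus stands lowest of the two numbers, and the only other number, that of compound 2, lies higher by more than the usual scatter of this assay. Within the data shown here, the two compounds differ in several places at once, so their pair gives no single step to read off.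

Compound 3 `CC(C)n1ncc2c(NCc3ccccc3[N+](=O)[O-])cc(C(F)(F)F)cc21` has not been measured in this assay. It differs from compound 1 in one place: isopropyl in place of 2-aminoethyl on an aromatic nitrogen. Among the measured compounds shown here, nothing among the measured compounds shows what an isopropyl in place of a 2-aminoethyl on an aromatic nitrogen does here; compound 2 carries a different core substitution and does not help. With compound 1 at 9% as the only anchor, the step from compound 1 to compound 3 is expected to be small, a number 3 percentage points higher from compound 1 to compound 3 (within the scatter), in no settled direction and not beyond the scatter. For compound 3 the expected value in this assay is 12%, with a range from 0% to 30%.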

Compound 3, a percentage reported as inhibition, at one concentration (the size of the read-out at that concentration, not a potency): 7%
Estimate against measurement, compound 3: 5 percentage points above; the measured number falls inside the stated range.
By their numbers in this assay, from the lowest: compounds 3 and 1 (each within the scatter of the next); then compound 2.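

In this assay, this position now has its first step that can be read: a number 2 percentage points lower from compound 1 to compound 3 (within the scatter), with isopropyl in place of 2-aminoethyl on an aromatic nitrogen of the five-membered aromatic ring. The group that leaves carries a nitrogen, a hydrogen-bond donor and a hydrogen-bond acceptor, the group that enters carries only carbon, and with the heavy-atom count the same, this exchange on the core of compound 1 leaves the read-out within the scatter, so the amine of 2-aminoethyl is not needed to reach this level. No measurement on hand speaks to why the two numbers lie together.

From the compounds shown here alone, what a carboxylic acid, a longer chain or a plain hydrogen at this nitrogen would give on the core of compound 1 stays open, since two groups at one position at this low level say little about the range of the position. Compound 2 differs from both of the others in several places, so steps to it cannot be read, and its 33% in this assay cannot be tied to any single part of its structure.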